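Adding tert-butyl to compound 1

The source may hold more compounds than are shown below. What is called first, only, known or untested is meant among the compounds shown, and "the series" means these compounds.

In a functional assay on AGS cells (Homo sapiens) for inhibition, read by reporter gene assay (on this read-out lower numbers stand for stronger inhibition and higher numbers for weaker inhibition), compound 1 (`O=C(COc1ccccc1)Nc1cccc(C(=O)O)c1`) gives > 30000 nM as its result, which is a limit of the assay and not a number. Compound 2 (`Cc1ccc(OCC(=O)Nc2cccc(C(=O)O)c2)cc1`) gives > 30000 nM as its result, also a limit. Compound 3 (`CC(C)(C)c1ccc(OCC(=O)Nc2cccc(C(=O)O)c2)cc1`) differs from compound 1 by tert-butyl in place of hydrogen on an aromatic carbon as tert-butyl in place of hydrogen on an aromatic carbon, para to a large group. Among the measured compounds shown here, the only measured step is a step that the two limits leave unreadable from compound 1 to compound 2 and it offers no size to carry over, so only a modest gain in inhibition is expected. The estimated change is an at least 1.2-fold lower number from compound 1 to compound 3 (0.07 log units; that floor lies within the scatter) and it may well stay hidden behind a limit. For compound 3 the estimated value is 25000 nM with an expected range from 8000 nM to 60000 nM overall.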

Compound 3, half-maximal inhibitory concentration: 9500 nM
Estimate against measurement, compound 3: 2.6-fold (0.42 log units) above; low and high end bracket the measured number.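

In this assay, compound 3 is the first compound here to give a true number, so this aromatic carbon, para to a large group, is now shown to be a place where a change can strengthen inhibition. Tert-butyl in place of hydrogen gives an at least 3.1-fold lower number from compound 1 to compound 3 (0.49 log units; beyond the scatter), and tert-butyl in place of methyl gives an at least 3.1-fold lower number from compound 2 to compound 3 (0.49 log units; beyond the scatter). Both sizes are only floors, set by a limit of the assay: the limit of > 30000 nM in this assay, at which 2 of the 3 values shown sit.

From the compounds shown here alone, the step from compound 1 to compound 2 cannot be read, so the effect of methyl here stays unknown. Going by these compounds, whether a chlorine atom, a methoxy group or a cyclohexyl group at this place would match tert-butyl also stays open.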